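This account rests on a few compounds, and the source may have more. Where it says the series, first, only, none or still open, it means among the compounds named here.

For the measured compounds named here, the three compounds measured so far share one core and were all tested in a physicochemical assay for solubility, at pH 7; on this read-out higher numbers stand for higher solubility and lower numbers for lower solubility. Compound 1 `CN1CCC(C(=O)N2Cc3c(NC(=O)c4ccsc4)n[nH]c3C2(C)C)CC1` gives > 225000 nM, which is a limit of the assay rather than a number. Compound 2 `CC(C)CC(=O)Nc1n[nH]c2c1CN(C(=O)C1CCN(C3CC3)CC1)C2(C)C` gives > 225000 nM, also a limit. Compound 3 `CC(C)(C)C(=O)N1Cc2c(NC(=O)C3CCNCC3)n[nH]c2C1(C)C` likewise gives > 225000 nM, a limit as well. So compound 1 stands where the others stand: the limit of > 225000 nM in this assay, at which 3 of the 3 values shown sit.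

Compound 4 `CN1CCC(C(=O)N2Cc3c(NC(=O)NCc4ccccc4)n[nH]c3C2(C)C)CC1` has not yet been measured. It differs from compound 1 by benzylamino in place of thiophen-3-yl on a carbonyl carbon. Going by the values given here, no pair of measured compounds shows how such a swap moves this read-out, so only the shared limit guides the outlook. The expected step is a number no higher from compound 1 to compound 4 (the limit leaves the size open), none beyond the scatter. Compound 4 is therefore expected to give about 225000 nM, within 90000 nM to 400000 nM.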

Compound 4, solubility: > 225000 nM
Compound 4: only a limit was reported (the forecaster's own chance of this, stated with the estimate: 65%); the middle value sits exactly at the limit.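

For the compounds shown here, compound 1 and compound 4 each gave only a limit rather than a number, so no step between them can be read. The compounds shown leave open which change to the shared core, if any, would give a readable number: the limit of > 225000 nM in this assay, at which 4 of the 4 values shown sit.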